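A few compounds are considered here, and "the series" means these few. Any claim that something is new, unique, unknown or untested is made for them only; others in the source may bear on it.

Measured so far:
compound 1 `COc1ccc(-c2nc(C)c(C(=O)CSc3nc(N)c(C#N)c(-c4ccc(Cl)cc4)n3)s2)cc1` — 39200 nM
compound 2 `Cc1nc(-c2ccccc2)sc1C(=O)CSc1nc(N)c(C#N)c(-c2ccc(Cl)cc2)n1` — "not determined" (no result reported)

In an ADME assay on HEK293 cells (Homo sapiens) for cytotoxicity, read by MTT assay, with a stated time of 48 h (on this read-out lower numbers stand for stronger inhibition and higher numbers for weaker inhibition), compound 1 gives 39200 nM. Compound 2 has no number in this assay, so it stands nowhere on the scale shown; only compound 1 anchors the series. Compound 3 `Cc1nc(-c2ccc(Cl)cc2)sc1C(=O)CSc1nc(N)c(C#N)c(-c2ccc(Cl)cc2)n1` differs from compound 2 by chloro in place of hydrogen on an aromatic carbon. With no measured step of this kind in the set, no direction can be read off, and no step beyond the scatter in this assay is expected for compound 3. Against the single anchor of compound 1, compound 3 is expected near 40000 nM, within 15000 nM to 100000 nM.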

Compound 3, half-maximal inhibitory concentration: 73000 nM
Beside the measured number, compound 3's estimate is 1.8-fold (0.26 log units) below it; low and high end bracket the measured number.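

In this assay, among these compounds, chloro in place of methoxy on the aromatic carbon gives a 1.9-fold higher number from compound 1 to compound 3 (0.27 log units; within the scatter), the first step that can be read at this position. The change from phenyl to 4-chlorophenyl cannot be read, as compound 2 has no number. No measurement available here speaks to a cause for this result. Still open, on these data alone, is whether an amine, a carboxylic acid or a longer chain on this aromatic carbon would give a step beyond the scatter. Changes elsewhere on the shared core also remain open.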